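The source may report more compounds than this note shows. Statements on the series, on what has been measured and on what is new or still open speak of the compounds shown alone.

Compound 1 `CCCC(=O)Oc1ccc2oc(/C=C/[S+](C)[O-])cc(=O)c2c1`: 2200 nM
Compound 2 `Cc1ccc2oc(/C=C/[S+](C)[O-])cc(=O)c2c1`: 1700 nM
Compound 3 `CCCCOc1ccc2oc(/C=C/[S+](C)[O-])cc(=O)c2c1`: 1400 nM
Compound 4 `CCC(=O)Oc1ccc2oc(/C=C/[S+](C)[O-])cc(=O)c2c1`: not yet measured

In a functional assay on A549 cells (Homo sapiens) for cytotoxicity, with a stated time of 48 h (a higher number here means a weaker inhibitor, a lower number a stronger inhibitor), compound 3 gives 1400 nM, and its steps to the other two compounds all stay within the scatter, so it cannot be ranked apart from them. Compound 4 carries propanoyl in place of butyl on an oxygen on an aromatic ring. The closest measured change is a 1.6-fold lower number from compound 1 to compound 3 (0.20 log units; within the scatter), which exchanges the same kinds of group on that oxygen in the opposite direction. The other steps, a 1.3-fold lower number from compound 1 to compound 2 (0.11 log units; within the scatter) and a 1.2-fold lower number from compound 2 to compound 3 (0.08 log units; within the scatter), are also small. A small move towards a higher number is therefore expected, with nothing beyond the scatter. The estimated change is a 1.4-fold higher number from compound 3 to compound 4 (0.13 log units; within the scatter). The expected value for compound 4 is 1900 nM, within a range of 1000 nM to 3500 nM.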

Compound 4, half-maximal inhibitory concentration: 2400 nM
Beside the measured number, compound 4's estimate is 1.3-fold (0.10 log units) below it; low and high end bracket the measured number.
By their numbers in this assay, from the lowest: compounds 3, 2, 1 and 4 (each within the scatter of the next).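

In this assay, putting propanoyl in place of butyl on the oxygen gives a 1.7-fold higher number from compound 3 to compound 4 (0.23 log units; within the scatter), and putting propanoyloxy in place of methyl on the aromatic carbon gives a 1.4-fold higher number from compound 2 to compound 4 (0.15 log units; within the scatter). Taking one carbon off the chain of compound 1 gives a 1.1-fold higher number from compound 1 to compound 4 (0.04 log units; within the scatter), so a shorter carbonyl-bearing chain also stays within the scatter, as do the other changes at this position. No measurement available here explains these results. Still open, going by these compounds, is whether an amine, a carboxylic acid or a much longer chain at this position would move the number beyond the scatter.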